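From 4-Chlorophenyl to Pyrrolidin-3-yl on the Carbonyl Carbon

The compounds below may be only part of what the source reports. "The series", "measured", "known", "first", "only" and "open" are said of these compounds alone.

Three compounds sharing one core have been measured in a physicochemical assay for solubility; on this read-out higher numbers stand for higher solubility and lower numbers for lower solubility:

Compound 1, `O=C(c1ccc(Cl)cc1)N1CCC(NS(=O)(=O)c2cc(S(=O)(=O)c3ccccc3)ccc2C(F)(F)F)CC1`, gives 3100 nM.
Compound 2, `O=C(O)c1cccc(S(=O)(=O)N2CCC(NS(=O)(=O)c3cc(S(=O)(=O)c4ccccc4)ccc3C(F)(F)F)CC2)c1`, gives 12500 nM.
Compound 3, `O=C(O)CCCC(=O)N1CCC(NS(=O)(=O)c2cc(S(=O)(=O)c3ccccc3)ccc2C(F)(F)F)CC1`, gives 50000 nM.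

Compound 1 stands lowest of the three. Two measured steps start from it: a 4.0-fold higher number from compound 1 to compound 2 (0.61 log units; beyond the scatter), and a 16-fold higher number from compound 1 to compound 3 (1.21 log units; beyond the scatter). Between the other two, a 4.0-fold higher number from compound 2 to compound 3 (0.60 log units; beyond the scatter).

Compound 4, `O=C([C@@H]1CCNC1)N1CCC(NS(=O)(=O)c2cc(S(=O)(=O)c3ccccc3)ccc2C(F)(F)F)CC1`, is the next candidate. Relative to compound 1 the change is pyrrolidin-3-yl in place of 4-chlorophenyl on a carbonyl carbon. For the measured compounds named here, of the measured steps, the one from compound 1 to compound 3 bears on it most directly, since it too exchanges the 4-chlorophenyl on the carbonyl carbon for a non-aromatic group; the step from compound 1 to compound 2 is a second, smaller pointer in the same direction. On this basis compound 4 is expected to lie well above compound 1 in this assay, with an estimated step of a 9.7-fold higher number from compound 1 to compound 4 (0.99 log units; beyond the scatter), though the exact size is uncertain because the steps of a 4.0-fold higher number from compound 1 to compound 2 (0.61 log units; beyond the scatter) and a 16-fold higher number from compound 1 to compound 3 (1.21 log units; beyond the scatter) differ widely. The estimate for compound 4 is 30000 nM, within a range from 8000 nM to 110000 nM.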

Compound 4, solubility: 12500 nM
Beside the measured number, compound 4's estimate is 2.4-fold (0.38 log units) above it, within the range that was stated.
By their numbers in this assay, from the lowest: compound 1; then compounds 2 and 4 (each within the scatter of the next); then compound 3.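

In this assay, pyrrolidin-3-yl on the carbonyl carbon gives a 4.0-fold higher number from compound 1 to compound 4 (0.61 log units; beyond the scatter), so among the compounds shown a higher number at this position does not depend on a carboxylic acid. For the compounds shown here, the non-aromatic ring does not match the open chain, however: the exchange of 3-carboxypropyl for pyrrolidin-3-yl gives a 4.0-fold lower number from compound 3 to compound 4 (0.60 log units; beyond the scatter), the one step in this set that lowers the number at this carbonyl carbon. The comparison with the sulfonyl-linked acid gives no change at the digits printed from compound 2 to compound 4 (within the scatter), so (pyrrolidin-3-yl)carbonyl and (3-carboxyphenyl)sulfonyl cannot be told apart on this read-out.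

On these data alone, whether the ring nitrogen matters stays open, and a cyclopentyl group on the same carbonyl carbon would test this directly. The opposite stereocentre of pyrrolidin-3-yl and an open-chain amine also remain unaddressed. Nothing available here offers a cause for these steps.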